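The source may report more compounds than this note shows. Statements on the series, on what has been measured and on what is new or still open speak of the compounds shown alone.

Of the compounds shown here, two built on a shared core have been measured in an ADME assay on HepG2 2.2.15 cells (Homo sapiens) for cytotoxicity; on this read-out lower numbers stand for higher toxicity in this test and higher numbers for lower toxicity in this test. Compound 1 `O=c1[nH]c2ccc(Cl)cc2c(-c2ccccc2Cl)c1CCO` gives 1720000 nM in this assay. Compound 2 `O=c1cc(-c2ccccc2F)c2cc(Cl)ccc2[nH]1` stands at the limit of > 5460000 nM in this assay, at which 1 of the 2 values shown sits. In this assay compound 2 gives > 5460000 nM, which is a limit of the test and not a number. Compound 3 `O=c1[nH]c2ccc(Cl)cc2c(-c2ccccc2F)c1CCO` differs from compound 2 by 2-hydroxyethyl in place of hydrogen on an aromatic carbon, in words a 2-hydroxyethyl in place of hydrogen on an aromatic carbon. Within the data shown here, no step between the measured compounds is available, so the expectation rests on compound 1, which carries the same 2-hydroxyethyl group and gives 1720000 nM in this assay. The expected step is an at least 2.1-fold lower number from compound 2 to compound 3 (0.33 log units; beyond the scatter), a move from a limit toward a measurable value, though this assay may again report only a limit. Compound 3 is estimated at 2500000 nM, with a range from 1000000 nM to 6000000 nM.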

Compound 3, half-maximal cytotoxic concentration: > 2990000 nM
Compound 3: no number, only a limit; the forecaster's own chance of this, stated with the estimate: 45%; at least 1.1-fold (0.07 log units) between middle value and limit.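

In this assay compound 3 gives > 2990000 nM, which is a limit of the test and not a number. With compound 2 also ending at a limit, the step for 2-hydroxyethyl in place of hydrogen on this aromatic carbon cannot be read, so the data no longer support any firm lowering of the number by this group. Among these compounds, the one readable comparison, fluoro in place of chloro on an aromatic carbon, gives an at least 1.7-fold higher number from compound 1 to compound 3 (0.24 log units; that floor lies within the scatter), which leaves the size of that change undetermined.

As far as these compounds go, whether the true value of compound 3 lies on one side or the other of that of compound 2 stays open. From the compounds shown here alone, it is also open whether an amine, a carboxylic acid or a longer chain at this position would give a number rather than a limit in this assay.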